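A few compounds are considered here, and "the series" means these few. Any claim that something is new, unique, unknown or untested is made for them only; others in the source may bear on it.

Measured so far in a functional assay on the whole organism with Mus musculus as the target; on this read-out lower numbers stand for an effect already at smaller amounts and higher numbers for an effect only at larger amounts of compound:
Compound 1 `CC1(C)Cc2cc(N)ccc2O1` gives > 100 mg/kg as a limit of the assay
Compound 2 `Cc1c(C)c2c(c([N+](=O)[O-])c1N)CC(C)(C)O2` gives > 100 mg/kg as a limit of the assay
Compound 3 `Cc1c(C)c2c(c(C)c1N)CC(C)(CSc1ccc(F)cc1)O2` gives 17.9 mg/kg as a measured number

Within the data shown here, compound 3 at 17.9 mg/kg is the only number in the set. Compound 4 `CCCSCC1(C)Cc2c(C)c(N)c(C)c(C)c2O1` carries one change from compound 3, (propyl in place of 4-fluorophenyl on a sulfur), with propyl in place of 4-fluorophenyl on a sulfur. Among the measured compounds shown here, no measured pair isolates this change. In this assay no step beyond the scatter is expected, and the estimated 1.4-fold higher number from compound 3 to compound 4 (0.15 log units; within the scatter) is tentative. In this assay compound 4 is expected at 25 mg/kg with an estimated span from 8 mg/kg to 80 mg/kg as its range.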

Compound 4, dose for 50% inhibition: 24.6 mg/kg
For compound 4 the middle estimate is 1.0-fold (0.01 log units) above the measured one; low and high end bracket the measured number.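

The position on the sulfur now has its first measured pair in this assay: a 1.4-fold higher number from compound 3 to compound 4 (0.14 log units; within the scatter). At this place, the six-membered aromatic ring of 4-fluorophenyl is therefore not needed for a measured number in this range, as propyl, with no ring, stays within the scatter of it. Steps from this pair to compound 1 or compound 2 cannot be read: the limit of > 100 mg/kg in this assay, at which 2 of the 4 values shown sit.

Open, on these data alone, is whether an amine, a carboxylic acid or a longer chain on the sulfur would keep a number of this order. Also open, as far as these compounds go, is what an oxygen in place of the sulfur would give.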